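Swapping fluoro for methoxy on a chalcone scaffold

The source may report more compounds than this note shows. Statements on the series, on what has been measured and on what is new or still open speak of the compounds shown alone.

Measured compounds:
compound 1 `Nc1ccc(C(=O)/C=C/c2ccc(O)c(F)c2)cc1-c1ccc(F)cc1` gives 24500 nM
compound 2 `COc1ccc(/C=C/C(=O)c2cccc(-c3cccc(F)c3)c2)cc1O` gives 500 nM
compound 3 `O=C(/C=C/c1cccc(-c2ccc(F)cc2)c1)c1ccc(O)cc1` gives 8360 nM

These three compounds were tested in a functional assay on A549 cells (Homo sapiens) for cytotoxicity, read by sulforhodamine B assay, with a stated time of 48 h; a higher number here means a weaker inhibitor, a lower number a stronger inhibitor. Compound 1 has the highest number of the three, so it is the weakest inhibitor shown. Compound 3 comes nearest, with a number that is lower by a margin beyond the scatter, and compound 2 is furthest, with a much lower number still.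

The unmeasured compound 4 `COc1cc(/C=C/C(=O)c2ccc(N)c(-c3ccc(F)cc3)c2)ccc1O` is reached from compound 1 by a single change: methoxy in place of fluoro on an aromatic carbon. Methoxy takes the place of fluoro on an aromatic carbon, ortho to a hydroxy group. For the measured compounds named here, no measured pair shows exactly this change, so its effect must be guessed. The same 4-hydroxy-3-methoxyphenyl group as in compound 4 is carried by compound 2, which gives 500 nM, but compound 2 differs from compound 4 elsewhere too, so this is weak guidance. A moderate drop in the number, beyond the scatter, is expected for the step of a 3.1-fold lower number from compound 1 to compound 4 (0.49 log units; beyond the scatter). Compound 4 is therefore estimated at 8000 nM, within a range from 2000 nM to 30000 nM.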

Compound 4, half-maximal inhibitory concentration: 12200 nM
Compound 4: the middle estimate sits 1.5-fold (0.18 log units) below what was measured; the measured number falls inside the stated range.
By their numbers in this assay, from the lowest: compound 2; then compounds 3, 4 and 1 (each within the scatter of the next, the first and the last beyond it).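

In this assay, changing 3-fluoro-4-hydroxyphenyl to 4-hydroxy-3-methoxyphenyl gives a 2.0-fold lower number from compound 1 to compound 4 (0.30 log units; within the scatter). For the compounds shown here, this is the first direct reading of the change, and it shows that on this core, at this place ortho to a hydroxy group, methoxy and fluoro cannot be told apart by this measurement. The step therefore gives no sign that this position, with either group, controls the result, and no measurement shown offers an explanation for this outcome.

Still open, as far as these compounds go, is whether a different group here, such as an amine, a chloro group or a longer ether such as ethoxy, would shift the number beyond the usual scatter. Also open, from the compounds shown here alone, is whether the same swap from fluoro to methoxy would give a similar result on a different core.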